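Aryl swap at the saturated ring carbon of the core

The source may hold more compounds than are shown below. What is called first, only, known or untested is meant among the compounds shown, and "the series" means these compounds.

Of the compounds shown here, two have been measured in a functional assay, with a stated time of 20 min, tested at 20 uM; a lower number here means a weaker effect, a higher number a stronger effect of the compound at the concentration tested. Among the compounds with values here, compound 1 `COc1cc(/C=C/C(=O)C2=C(/C=C/c3ccc(O)c(OC)c3)NC(=O)NC2c2ccccc2)ccc1O` gives 31%, and compound 2 `COc1cc(/C=C/C(=O)C2=C(/C=C/c3ccc(O)c(OC)c3)NC(=O)NC2c2ccc(C)cc2)ccc1O` gives 36.3%; the only change between them was a number 5.3 percentage points higher from compound 1 to compound 2 (within the scatter). Compound 2 therefore stands with the higher of the two numbers, though the gap to compound 1 is within the scatter. Compound 3 `COc1cc(/C=C/C(=O)C2=C(/C=C/c3ccc(O)c(OC)c3)NC(=O)NC2c2ccccc2O)ccc1O` differs from compound 2 in one place: 2-hydroxyphenyl in place of 4-methylphenyl on a saturated ring carbon. Within the data shown here, the single measured step bears only loosely on this change and was itself within the scatter, so no step beyond the scatter is expected in this assay, that is a number 2.3 percentage points lower from compound 2 to compound 3 (within the scatter). Compound 3 is accordingly estimated at 34%, with a range from 20% to 48%.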

Compound 3, a percentage reported as activity, at one concentration (the size of the read-out at that concentration, not a potency): 80.9%
Estimate against measurement, compound 3: 46.9 percentage points below, and the stated range ends below it.
By their numbers in this assay, from the lowest: compounds 1 and 2 (each within the scatter of the next); then compound 3.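

The aryl group on the saturated ring carbon is not a silent position in this assay: hydroxy in place of hydrogen on the aromatic carbon gives a number 49.9 percentage points higher from compound 1 to compound 3 (beyond the scatter), and 2-hydroxyphenyl in place of 4-methylphenyl gives a number 44.6 percentage points higher from compound 2 to compound 3 (beyond the scatter). The methyl change, a number 5.3 percentage points higher from compound 1 to compound 2 (within the scatter), showed no such response, so this ring does not answer to every change on it. No supporting data explain the size of these steps. Going by these compounds, whether the gain requires the hydroxy itself stays open: a 2-methoxyphenyl or 2-aminophenyl group on this carbon would test that.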